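Trifluoromethyl for Methyl on an Oxygen: Expectation for Compound 4

This account rests on a few compounds, and the source may have more. Where it says the series, first, only, none or still open, it means among the compounds named here.

Compound 1 `COc1ccc(/C=C/c2ccc3ccccc3c2)cc1` carries a methoxy group on one of its aromatic rings. In a functional assay on HT-29 cells (Homo sapiens) for inhibition (a higher number here means a weaker inhibitor, a lower number a stronger inhibitor), compound 1 gives only a limit, > 5000 nM. Compound 3 `FC(F)(F)Oc1ccc(/C=C/c2ccc3ccccc3c2)cc1` differs from it by trifluoromethyl in place of methyl on an oxygen on an aromatic ring. In this assay compound 3 likewise gives only a limit, > 5000 nM. The step that the two limits leave unreadable from compound 1 to compound 3 cannot be read because of the limit of > 5000 nM in this assay, at which 2 of the 3 values shown sit. Compound 2 `COc1cccc(/C=C\c2ccc3ccccc3c2)c1` has the same atoms as compound 1 joined differently; the difference between the two cores is not broken down here. In this assay, going by the values given here, compound 2 gives 1920 nM, the only number among the three measured values. Compound 4 `FC(F)(F)Oc1cccc(/C=C\c2ccc3ccccc3c2)c1` has not been measured; it differs from compound 2 by trifluoromethyl in place of methyl on an oxygen on an aromatic ring, the same change as from compound 1 to compound 3. Since that earlier step gave no size, the expectation rests on compound 2 alone. Compound 4 is expected near 2500 nM, between 800 nM and 6000 nM. The expected step of a 1.3-fold higher number from compound 2 to compound 4 (0.11 log units; within the scatter) is kept small for lack of a readable precedent.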

Compound 4, half-maximal inhibitory concentration: 3500 nM
For compound 4 the middle estimate is 1.4-fold (0.15 log units) below the measured one; low and high end bracket the measured number.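

In this assay, putting trifluoromethyl in place of methyl on the oxygen gives a 1.8-fold higher number from compound 2 to compound 4 (0.26 log units; within the scatter), so on the core of compound 2 the two groups cannot be told apart. This single readable step shows what the change does on that one core, but it does not show that the change behaves the same way on another core. The same change from compound 1 to compound 3 cannot be read, because both values are limits and not numbers: the limit of > 5000 nM in this assay, at which 2 of the 4 values shown sit.

The compounds shown leave open how a longer chain, such as ethyl, would read on the same oxygen. They also leave open what an amine or a carboxylic acid in place of the methoxy group would give on either core.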